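The source may report more compounds than this note shows. Statements on the series, on what has been measured and on what is new or still open speak of the compounds shown alone.

Working notes on the series.

In a functional assay on MDA-MB-231 cells (Homo sapiens) for antiproliferative activity, with a stated time of 4 days (on this read-out higher numbers stand for weaker inhibition and lower numbers for stronger inhibition), compound 1 `COc1ccc(-c2[nH]c3ccc(C(C)C)cc3c2C=O)cc1` gives 29 nM. Compound 2 `COc1ccc(-c2[nH]c3ccc(C(C)(C)C)cc3c2C=O)cc1` carries the change (methyl in place of hydrogen on a saturated chain carbon bound to an aromatic carbon and two saturated chain carbons); in this assay compound 2 gives 280 nM, and the step of a 9.7-fold higher number from compound 1 to compound 2 (0.98 log units; beyond the scatter). Compound 3 `CCCCc1ccc2[nH]c(-c3ccc(C)cc3)c(C=O)c2c1` gives 34 nM in this assay, a number close to that of compound 1; the difference between the two cores is not broken down here.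

Compound 4 `CCCCc1ccc2[nH]c(-c3ccc(CC)cc3)c(C=O)c2c1` is not yet measured. It differs from compound 3 by methyl in place of hydrogen on a saturated chain carbon bound to an aromatic carbon. This is the same kind of change as that from compound 1 to compound 2, but not the same: there the place was on a saturated chain carbon bound to an aromatic carbon and two saturated chain carbons, whereas here it is on a saturated chain carbon bound to an aromatic carbon.

For compound 4 the expected step is a 1.5-fold higher number from compound 3 to compound 4 (0.17 log units; within the scatter). Going by the values given here, the single earlier step was a loss, but its place differed, and only compound 1 and compound 2 inform it, so a smaller move is estimated. Compound 4 is expected at 50 nM, likely between 15 nM and 170 nM.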

Compound 4, half-maximal inhibitory concentration: 27 nM
Compound 4: the middle estimate sits 1.9-fold (0.27 log units) above what was measured, within the range that was stated.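

In this assay the change of methyl in place of hydrogen gives a 1.3-fold lower number from compound 3 to compound 4 (0.10 log units; within the scatter) and leaves the number within the scatter, whereas the earlier step gives a 9.7-fold higher number from compound 1 to compound 2 (0.98 log units; beyond the scatter) on the other core. The result of this change therefore does not carry from the core of compound 1 to the core of compound 3, and the two steps clearly differ: the same change on two cores in this assay, a 9.7-fold higher number (0.98 log units; beyond the scatter) from compound 1 to compound 2 and a 1.3-fold lower number (0.10 log units; within the scatter) from compound 3 to compound 4, 12-fold (1.08 log units) apart, beyond the scatter of two such steps. Going by these compounds alone, this does not show whether the core or the place of the change accounts for the gap, as the carbon taking the methyl has different neighbours in the two pairs and each core offers only one pair, so no general rule for the series follows.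

Going by these compounds, it remains open whether a longer chain than ethyl, or an amine or a carboxylic acid, in the place of this change would leave the number of compound 3 within the scatter. On these data alone, it also remains open how methyl in place of hydrogen on a saturated chain carbon bound to an aromatic carbon would read on the core of compound 1, a comparison that would separate place from core.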